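The compounds below may be only part of what the source reports. "The series", "measured", "known", "first", "only" and "open" are said of these compounds alone.

Compound 1 `COc1cccc(NC(=S)N/N=C/c2ccc3ccccc3n2)c1` stands at the highest of the two numbers measured in a functional assay on HeLa cells (Homo sapiens) for antiproliferative activity, read by sulforhodamine B assay, with a stated time of 72 h (on this read-out higher numbers stand for weaker inhibition and lower numbers for stronger inhibition), where compound 1 gives 74500 nM. Compound 2 `Cc1csc2sc(/C=N/NC(N)=S)c(C)c12`, built on a different core, gives 1120 nM in this assay, a far lower number than compound 1 shows. Compound 3 `S=C(N/N=C/c1ccc2ccccc2n1)Nc1ccccc1Br` differs from compound 1 by 2-bromophenyl in place of 3-methoxyphenyl on an amide-type nitrogen. For the measured compounds named here, no measured pair isolates this change, so only a small step toward a lower number is expected, a 2.1-fold lower number from compound 1 to compound 3 (0.33 log units; beyond the scatter) in this assay. Compound 3 is therefore estimated at 35000 nM, with a likely range of 8000 nM to 150000 nM.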

Compound 3, half-maximal inhibitory concentration: > 100000 nM
Compound 3 gave a limit, no number; the forecaster's own chance of this, stated with the estimate: 10%; middle value at least 2.8-fold (0.45 log units) away from the limit.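

Placing 2-bromophenyl instead of 3-methoxyphenyl on the amide-type nitrogen gives an at least 1.3-fold higher number from compound 1 to compound 3 (0.12 log units; that floor lies within the scatter) in this assay and so brings no move toward a lower number. For the compounds shown here, this is the first read at this position, and the swap gives no gain in antiproliferative activity. The result for compound 3 is a limit of the assay and not a number: the limit of > 100000 nM in this assay, at which 1 of the 3 values shown sits.

As far as these compounds go, how far compound 3 lies past that limit stays open. So does whether 3-bromophenyl, 2-methoxyphenyl or a simple ethyl chain on this nitrogen would give a lower number.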